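A few compounds are considered here, and "the series" means these few. Any claim that something is new, unique, unknown or untested is made for them only; others in the source may bear on it.

Measured in a functional assay on HCT-116 cells (Homo sapiens) for inhibition, read by MTT assay, with a stated time of 72 h; a lower number here means a stronger inhibitor of growth, a higher number a weaker inhibitor of growth:
- compound 1 `COc1ccc(-c2nc3c(N4CCN(Cc5cc(C)on5)CC4)c(Br)cnc3[nH]2)cc1` gives 540 nM
- compound 2 `Cc1cc(CN2CCN(c3c(Cl)cnc4[nH]c(-c5ccc(CN)cc5)nc34)CC2)no1` gives 650 nM
- compound 3 `Cc1cc(CN2CCN(c3c(Br)cnc4[nH]c(-c5ccc(OCCO)cc5)nc34)CC2)no1` gives 280 nM

Compound 3 at 280 nM lies within the scatter of compound 1 and beyond the scatter below compound 2. The next change is aminomethyl in place of 2-hydroxyethoxy on an aromatic carbon and leads to compound 4 `Cc1cc(CN2CCN(c3c(Br)cnc4[nH]c(-c5ccc(CN)cc5)nc34)CC2)no1`, with aminomethyl in place of 2-hydroxyethoxy on an aromatic carbon. Going by the values given here, the one measured step on this chain, a 1.9-fold lower number from compound 1 to compound 3 (0.29 log units; within the scatter), says little about replacing it. With aminomethyl too, and with chlorine where compound 3 has bromine, compound 2 gives 650 nM, so a modest move to a higher number is expected in this assay. The expected change is a 1.8-fold higher number from compound 3 to compound 4 (0.25 log units; within the scatter). Compound 4 is estimated at 500 nM, with an expected range of 220 nM to 1100 nM.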

Compound 4, concentration for 50% growth inhibition: 240 nM
Compound 4: the middle estimate sits 2.1-fold (0.32 log units) above what was measured; low and high end bracket the measured number.
By their numbers in this assay, from the lowest: compounds 4, 3, 1 and 2 (each within the scatter of the next, the first and the last beyond it).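

In this assay, 4-(2-hydroxyethoxy)phenyl and 4-(aminomethyl)phenyl cannot be told apart, with a 1.2-fold lower number from compound 3 to compound 4 (0.07 log units; within the scatter), while aminomethyl in place of methoxy on the same aromatic carbon gives a 2.3-fold lower number from compound 1 to compound 4 (0.35 log units; beyond the scatter). With aminomethyl held, bromo in place of chloro gives a 2.7-fold lower number from compound 2 to compound 4 (0.43 log units; beyond the scatter), the only step shown at the halogen. No evidence on the cause of these steps is available.

Going by these compounds, whether a carboxylic acid or a longer aminoalkyl chain would fit this position remains open. So does whether the bromo-for-chloro step holds with 2-hydroxyethoxy or methoxy in place of aminomethyl.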